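Enlarging the Amide of Compound 3: an Expectation

The compounds below may be only part of what the source reports. "The series", "measured", "known", "first", "only" and "open" are said of these compounds alone.

Compound 1 `CC(C)c1cc(C(C)(C)C)cc(-c2cccc(N(C)C)c2)c1CO` and compound 2 `CC(C)c1cc(C(C)(C)C)cc(-c2cccc(Cl)c2)c1CO` share one core; in a functional assay on RKE cells for antagonist activity at Vasoactive intestinal polypeptide receptor 1 (Rattus norvegicus), read by HTRF and cAMP accumulation, with stated times of 10 min and 30 min (on this read-out lower numbers stand for stronger inhibition and higher numbers for weaker inhibition), compound 1 gives 310 nM and compound 2 gives 100 nM. Within the data shown here, the only measured step, a 3.1-fold lower number from compound 1 to compound 2 (0.49 log units; beyond the scatter), concerns an aromatic substituent on that core. Compound 3 `CC(=O)Nc1sc2c(c1C#N)CCCC2` rests on a different core, and in this assay compound 3 gives 13000 nM, the highest of the three numbers, separated from both others by more than the scatter. Compound 4 `N#Cc1c(NC(=O)C2CCC2)sc2c1CCCC2` differs from compound 3 by cyclobutyl in place of methyl on a carbonyl carbon. Among the measured compounds shown here, no measured step touches this core or an acyl group, so the chloro step offers no guide. Compound 4 is therefore expected to show a 1.4-fold lower number from compound 3 to compound 4 (0.16 log units; within the scatter), nothing beyond the scatter. Compound 4 is estimated at 9000 nM, between 2500 nM and 30000 nM.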

Compound 4, half-maximal inhibitory concentration: 1800 nM
The estimate for compound 4 lay 5.0-fold (0.70 log units) above the measured number; the whole stated range lies above it.
By their numbers in this assay, from the lowest: compound 2; then compound 1; then compound 4; then compound 3.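

On this core the group on the carbonyl carbon is not a silent position: in this assay cyclobutyl in place of methyl gives a 7.2-fold lower number from compound 3 to compound 4 (0.86 log units; beyond the scatter) and so moves the number beyond the scatter. The earlier compounds shown here offered no step at this position, and the chloro step on the core of compound 1 said nothing about it. No evidence is available on what lies behind this step.

A single pair cannot separate the ring from the added carbons, so an open-chain butyl group would be informative. As far as these compounds go, whether cyclopentyl, phenyl or an amine at this carbonyl carbon would lower the number further remains open.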